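Methylsulfonyl replacing methyl in the acylsulfonamide series

A few compounds are considered here, and "the series" means these few. Any claim that something is new, unique, unknown or untested is made for them only; others in the source may bear on it.

Measured compounds:
Compound 1 `CN(C)CC[C@H](CSc1ccccc1)Nc1ccc(S(=O)(=O)NC(=O)c2ccc(N3CCN(Cc4ccccc4-c4ccc(Cl)cc4)CC3)cc2)cc1C(F)(F)F`: in an assay on isolated protein for displacement of a labelled ligand from Apoptosis regulator Bcl-2 (Homo sapiens), read by fluorescence polarization (a higher number here means a weaker inhibitor, a lower number a stronger inhibitor), compound 1 gives < 1 nM, which is a limit of the assay and not a number.
Compound 2 `Cc1cc(S(=O)(=O)NC(=O)c2ccc(N3CCN(Cc4ccccc4-c4ccc(Cl)cc4)CC3)cc2)ccc1N[C@H](CCN(C)C)CSc1ccccc1`: in this assay compound 2 gives < 1 nM, again a limit of the assay.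
Compound 3 `CN(C)CC[C@H](CSc1ccccc1)Nc1ccc(S(=O)(=O)NC(=O)c2ccc(N3CCN(CC4=C(c5ccc(Cl)cc5)CCCCC4)CC3)cc2)cc1[N+](=O)[O-]`: in this assay compound 3 gives < 1 nM, also a limit of the assay.

Compound 2 therefore stands at the floor of what this assay reports, and the same holds for compound 1 and compound 3, so no order among the three can be read. Within the data shown here, the only measured step that reaches compound 2, a step that the two limits leave unreadable from compound 1 to compound 2, stays unsized because the limit of < 1 nM in this assay, at which 3 of the 3 values shown sit, hides both of its ends.

Compound 4 `CN(C)CC[C@H](CSc1ccccc1)Nc1ccc(S(=O)(=O)NC(=O)c2ccc(N3CCN(Cc4ccccc4-c4ccc(Cl)cc4)CC3)cc2)cc1S(C)(=O)=O` differs from compound 2 by methylsulfonyl in place of methyl on an aromatic carbon. Among the measured compounds shown here, no measured step involves a methylsulfonyl, and the one step at this position is the unreadable one above, so the data give no direction for the change. With all three neighbours at the limit, the step from compound 2 to compound 4 is expected to be a step that the limit leaves unreadable from compound 2 to compound 4, that is, no movement that the assay could resolve. Compound 4 is accordingly estimated at 0.8 nM, within 0.2 nM to 3 nM, and would most likely again be reported only as a limit.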

Compound 4, inhibition constant: < 1 nM
Compound 4: a limit, no number; the forecaster's own chance of this, stated with the estimate: 70%; the middle value does not contradict the limit.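

In this assay compound 4 gives < 1 nM, a limit of the assay and not a number. The steps to compound 4 from compound 1 and compound 2 cannot be read, because each has a limit at both ends: the limit of < 1 nM in this assay, at which 4 of the 4 values shown sit.

On these data alone, whether methylsulfonyl, methyl and trifluoromethyl differ at all in this assay remains open, as does any order among the four compounds.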